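This account rests on a few compounds, and the source may have more. Where it says the series, first, only, none or still open, it means among the compounds named here.

Compound 1 `CCCC(Oc1ccc(-n2cc(Cl)cn2)cc1)c1ccc(C(=O)NCCC(=O)O)cc1` gives 10 mL/min/kg in an ADME assay on microsomes from liver (Homo sapiens) for metabolic stability; a higher number here means faster removal of the compound, a lower number slower removal. Compound 2 `CCCC(Oc1ccc(-n2cc(F)cn2)cc1)c1ccc(C(=O)NCCC(=O)O)cc1` gives 12 mL/min/kg. Compound 3 `CCCC(Oc1ccc(-n2cc(C(F)(F)F)c(C)n2)cc1)c1ccc(C(=O)NCCC(=O)O)cc1` reaches only a limit of the assay, < 10 mL/min/kg, so no number is known for it.

Among the two numbers, compound 1 stands lowest, with compound 2 nearest: a 1.2-fold higher number from compound 1 to compound 2 (0.08 log units; within the scatter). Compound 4 `CCCC(Oc1ccc(-n2cc(OC)cn2)cc1)c1ccc(C(=O)NCCC(=O)O)cc1` is not yet measured; it departs from compound 1 by methoxy in place of chloro on an aromatic carbon. The steps known from compound 1 are small: the halogen swap gives a 1.2-fold higher number from compound 1 to compound 2 (0.08 log units; within the scatter), and the larger exchange gives a number no higher from compound 1 to compound 3 (the limit leaves the size open), whose size the limit leaves open. Nothing here points beyond the scatter, so compound 4 is expected to show a 1.2-fold higher number from compound 1 to compound 4 (0.08 log units; within the scatter). Compound 4 is therefore estimated at 12 mL/min/kg, with a range from 7 mL/min/kg to 22 mL/min/kg.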

Compound 4, clearance in the Homo sapiens assay: < 8 mL/min/kg
Compound 4 was reported as a limit; the forecaster's own chance of this, stated with the estimate: 25%; middle value at least 1.5-fold (0.17 log units) away from the limit.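

With methoxy on this aromatic carbon, the Homo sapiens assay gives only a limit for compound 4, so the steps are floors that lie within the scatter: an at least 1.2-fold lower number from compound 1 to compound 4 (0.09 log units; that floor lies within the scatter) and an at least 1.5-fold lower number from compound 2 to compound 4 (0.17 log units; that floor lies within the scatter). The step between compound 3 and compound 4 joins two limits and cannot be read. In a physicochemical assay for lipophilicity, using the shake flask method, at pH 7.4 (a higher number here means a more lipophilic compound, a lower number a more polar compound), compound 1 gives 2.6 and compound 4 gives 1.4, so this exchange moves that read-out beyond the scatter.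

On these data alone, the true size of the change in the Homo sapiens assay stays open. So does the result of an amine or a longer alkoxy chain on this carbon.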